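A few compounds are considered here, and "the series" means these few. Any claim that something is new, unique, unknown or untested is made for them only; others in the source may bear on it.

Among the compounds with values here, in an assay on CHO cells for displacement of a labelled ligand from adenosine receptor A3 (Homo sapiens), read by scintillation counting, tested at 1 uM (a higher number here means more inhibition at the concentration tested (going by the name of the read-out), a lower number less inhibition), compound 1 `CC(C)Cc1nc(N)c2nn(-c3ccccc3)cc2n1` gives 13% and compound 2 `Nc1nc(CCCc2ccccc2)nc2cn(-c3ccccc3)nc12` gives 12%; the step of a number 1 percentage points lower from compound 1 to compound 2 (within the scatter) is the only measured change, and the two values sit within the scatter of one another, so compound 2 stands lowest of two numbers but is not separated from compound 1. Compound 3 `C=CCOc1ccc(CCCc2nc(N)c3nn(-c4ccccc4)cc3n2)cc1` is the next member, differing from compound 2 by allyloxy in place of hydrogen on an aromatic carbon. Within the data shown here, no measured step touches that position or that kind of substituent; the one known step changed the chain on the core and moved this assay by nothing beyond the scatter. Absent any step that bears on the change, the working expectation for compound 3 in this assay is a step of about a number 1 percentage points higher from compound 2 to compound 3 (within the scatter), that is, no movement beyond the scatter. Compound 3 is therefore estimated at 13%, with a range from 2% to 28%.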

Compound 3, a percentage reported as inhibition, at one concentration (the size of the read-out at that concentration, not a potency): 3%
Compound 3: the middle estimate sits 10 percentage points above what was measured, within the range that was stated.
By their numbers in this assay, from the lowest: compounds 3, 2 and 1 (each within the scatter of the next).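

In this assay, within the data shown here, the change gives the first reading at this position, an aromatic carbon of a six-membered aromatic ring of carbon only, para to a large group: allyloxy in place of hydrogen is a number 9 percentage points lower from compound 2 to compound 3 (within the scatter). The earlier step concerned only the chain on the core, so this result extends the reading to the far end of that chain: a group of 4 heavy atoms with one double bond and one hydrogen-bond acceptor can stand here without a separation from the unsubstituted compound 2. Nothing measured bears on the reason for this outcome.

One substituent at one position leaves open whether this site is generally insensitive. A hydroxyl, an amine or a carboxylic acid at this carbon, or a longer chain in place of allyloxy, could still give a step beyond the scatter.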